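Swapping one ester group on a dihydropyridine calcium channel blocker

A few compounds are considered here, and "the series" means these few. Any claim that something is new, unique, unknown or untested is made for them only; others in the source may bear on it.

Compound 2 `CCOC(=O)C1=C(C)NC(C)=C(C(=O)OC(C)(C)C)C1c1csc(-c2ccc(Cl)cc2)n1` and compound 1 `CC1=C(C(=O)OC(C)(C)C)C(c2csc(-c3ccc(Cl)cc3)n2)C(C(=O)OC(C)(C)C)=C(C)N1` share a core and differ only in one ester group; ethyl in place of tert-butyl gave a 4.3-fold higher number from compound 1 to compound 2 (0.64 log units; beyond the scatter). In an assay on isolated protein for antagonist activity at Voltage-dependent L-type calcium channel subunit alpha-1C (Cavia porcellus), with a stated time of 15 min (a higher number here means a weaker inhibitor, a lower number a stronger inhibitor), compound 2 gives 91000 nM, the highest of the two numbers measured, while compound 1 gives 21000 nM. Compound 3 `CCOC(=O)C1=C(C)NC(C)=C(C(=O)OC(C)c2ccccc2)C1c1csc(-c2ccc(Cl)cc2)n1` is not yet measured. It differs from compound 2 in one place: 1-phenylethyl in place of tert-butyl on an oxygen next to a carbonyl group. Among the compounds with values here, the only measured step, from compound 1 to compound 2, concerns a different replacement on that oxygen, so it says little about a 1-phenylethyl group; it shows only that this position tolerates a change of the size seen in a 4.3-fold higher number from compound 1 to compound 2 (0.64 log units; beyond the scatter). The expectation for compound 3 is therefore a modest shift, direction uncertain, roughly a 1.8-fold lower number from compound 2 to compound 3 (0.26 log units; within the scatter). Compound 3 is estimated at 50000 nM, with a likely range from 15000 nM to 200000 nM.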

Compound 3, half-maximal inhibitory concentration: 13800 nM
Beside the measured number, compound 3's estimate is 3.6-fold (0.56 log units) above it, outside the stated range (below it).
By their numbers in this assay, from the lowest: compounds 3 and 1 (each within the scatter of the next); then compound 2.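

Putting 1-phenylethyl on this ester oxygen in place of tert-butyl gave a 6.6-fold lower number from compound 2 to compound 3 (0.82 log units; beyond the scatter) in this assay. Within the data shown here, the earlier step exchanged only tert-butyl and ethyl, neither of which has a ring, so this is the first sign that the position accepts a group with a six-membered aromatic ring and more heavy atoms, and that inhibition grows stronger with this swap. No supporting data are available to explain this shift.

The compounds shown leave open whether the aromatic ring, the larger number of carbons or the branching carbon that carries the ring goes with the stronger inhibition. They also leave open how a benzyl group, a longer carbon chain or a chain ending in an amine would behave on this same oxygen.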